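A few compounds are considered here, and "the series" means these few. Any claim that something is new, unique, unknown or untested is made for them only; others in the source may bear on it.

In a functional assay on DU-145 cells (Homo sapiens) for inhibition, read by trypan blue exclusion, with a stated time of 96 h (on this read-out lower numbers stand for stronger inhibition of growth and higher numbers for weaker inhibition of growth), compound 1 `Cc1ccsc1/C=C(/SCc1ccc(Cl)c(Cl)c1)C(=O)c1ccc(Cl)cc1` gives 50000 nM and compound 2 `O=C(/C(=C\c1c(O)cc(O)cc1O)SCc1ccc(Cl)c(Cl)c1)c1ccc(Cl)cc1` gives 25000 nM while compound 3 `CN(C)c1ccc(/C=C(/SCc2ccc(Cl)c(Cl)c2)C(=O)c2ccc(Cl)cc2)cc1` gives 50000 nM on the same read-out. Compound 3 thus stands level with compound 1, and compound 2 lies within the scatter of both. Compound 4 `COc1ccc(OC)c(/C=C(/SCc2ccc(Cl)c(Cl)c2)C(=O)c2ccc(Cl)cc2)c1` has not yet been measured. Its difference from compound 3 is 2,5-dimethoxyphenyl in place of 4-(dimethylamino)phenyl on a double-bonded chain carbon bound to a double-bonded chain carbon with 2,5-dimethoxyphenyl in place of 4-(dimethylamino)phenyl on a double-bonded chain carbon bound to a double-bonded chain carbon. The measured steps that bear on this exchange swap the group at that same place. They run a 2.0-fold lower number from compound 1 to compound 2 (0.30 log units; within the scatter) then no change at the digits printed from compound 1 to compound 3 (within the scatter) and a 2.0-fold higher number from compound 2 to compound 3 (0.30 log units; within the scatter) and all lie within the scatter. Among the measured compounds shown here, no measured compound carries the 2,5-dimethoxyphenyl group, so these steps are the only guide. No step beyond the scatter is therefore expected in this assay for this exchange. Compound 4 is estimated at 40000 nM with an expected range from 15000 nM to 80000 nM on this read-out. That estimate means a 1.3-fold lower number from compound 3 to compound 4 (0.10 log units; within the scatter) as the expected step, inside the scatter.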

Compound 4, concentration for 50% growth inhibition: 10000 nM
Beside the measured number, compound 4's estimate is 4.0-fold (0.60 log units) above it, outside the stated range (below it).
By their numbers in this assay, from the lowest: compound 4; then compounds 2, 1 and 3 (each within the scatter of the next).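

Until now, no exchange of the group on a double-bonded chain carbon bound to a double-bonded chain carbon had moved the number in this assay beyond the scatter, so this position had shown no measurable response. Among the compounds shown here, the 2,5-dimethoxyphenyl group is the first to do so, with a 5.0-fold lower number from compound 3 to compound 4 (0.70 log units; beyond the scatter) and a 5.0-fold lower number from compound 1 to compound 4 (0.70 log units; beyond the scatter), and the smaller 2.5-fold lower number from compound 2 to compound 4 (0.40 log units; beyond the scatter) is also beyond the scatter, which makes compound 4 the most potent of the four, although each step is only modest. Nothing in the available data accounts for these steps.

As far as these compounds go, it remains open whether both methoxy groups are needed, or whether a single methoxy group, as in 2-methoxyphenyl, or the longer ethoxy groups of 2,5-diethoxyphenyl would give a similar number. The rest of the core is the same in all four compounds, so it is also unknown whether this step would hold with other groups there.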